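A dimethylamino swap on a shared core

The compounds below may be only part of what the source reports. "The series", "measured", "known", "first", "only" and "open" are said of these compounds alone.

Within the data shown here, in a functional assay on the whole organism for inhibition, with Rattus norvegicus as the target (a higher number here means a weaker inhibitor, a lower number a stronger inhibitor), compound 1 `O=C1ON=C(c2cccs2)/C1=C/c1ccc(O)cc1` gives 4200 nM and compound 2 `O=C1ON=C(c2cccs2)/C1=C/c1ccc(Cl)cc1` gives 6200 nM, two values within the scatter of each other, so compound 2 stands level with the only other measured compound. Compound 3 `CN(C)c1ccc(/C=C2\C(=O)ON=C2c2cccs2)cc1` shares the core of compound 2 and differs by dimethylamino in place of chloro on an aromatic carbon, with dimethylamino in place of chloro on an aromatic carbon, para to a large group. Among the measured compounds shown here, only one measured step bears on this place, namely a 1.5-fold higher number from compound 1 to compound 2 (0.17 log units; within the scatter), with chloro in place of hydroxy, and it stays within the scatter. For the measured compounds named here, no measured compound carries dimethylamino, and this single step gives no direction, so no change beyond the scatter is expected in this assay. The expected change is a 1.2-fold lower number from compound 2 to compound 3 (0.09 log units; within the scatter), which lies within the scatter. Compound 3 is estimated at 5000 nM, with an expected range from 1800 nM to 14000 nM.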

Compound 3, half-maximal inhibitory concentration: 4200 nM
For compound 3 the middle estimate is 1.2-fold (0.08 log units) above the measured one; the range from low to high includes it.
By their numbers in this assay, from the lowest: compounds 1, 3 and 2 (each within the scatter of the next).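

In this assay, the new compound gives a 1.5-fold lower number from compound 2 to compound 3 (0.17 log units; within the scatter), and set against the hydroxy compound it gives no change at the digits printed from compound 1 to compound 3 (within the scatter), so all three groups at this place, on an aromatic carbon para to a large group, now stand within the scatter of one another. Dimethylamino brings three heavy atoms where chloro has one, and this larger count goes with no change beyond the scatter, which the earlier hydroxy and chloro pair could not show. Nothing available here explains why the numbers stay so close at this place.

The compounds shown leave open whether a carboxylic acid, a primary amine or a longer alkoxy chain at this place would move the number beyond the scatter. They also leave open how far changes elsewhere on the shared core would matter, since all three compounds keep it intact.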